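The source may report more compounds than this note shows. Statements on the series, on what has been measured and on what is new or still open speak of the compounds shown alone.

Measured so far:
compound 1, `O=C(NC1CCCC1)c1cc2ccccc2oc1=O` — 16%
compound 2, `COc1cccc2cc(C(=O)NC3CCCC3)c(=N)oc12` — > 70%

The account follows one change made to compound 1. For the measured compounds named here, in an assay on CHO cells for displacement of a labelled ligand from adenosine receptor A1 (Homo sapiens), read by scintillation counting, with a stated time of 60 min, tested at 10 uM (a lower number here means less inhibition, a higher number more inhibition at the concentration tested (going by the name of the read-out)), compound 1 gives 16%, the only plain number in this set, and the inhibition recorded for compound 1 in this assay at the concentration tested is a low number. Compound 2 is reported in this assay only as a limit, > 70%, and not as a number; the limit of > 70% in this assay, at which 1 of the 2 values shown sits, marks that one of the two values shown sits at this limit. Going by the values given here, no step between compound 1 and compound 2 is given, so the pair shows only a weak reading against a limit.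

Compound 3, `O=C(O)CNC(=O)c1cc2ccccc2oc1=O`, is not yet measured in this assay. Its difference from compound 1 is carboxymethyl in place of cyclopentyl on an amide-type nitrogen. Among the compounds with values here, since no measured step shares this change, the expectation rests on compound 1 alone, whose value 16% leaves little room below it. The step from compound 1 to compound 3 is expected to be small and downward, a number 7 percentage points lower from compound 1 to compound 3 (within the scatter), within the usual scatter. Compound 3 is therefore estimated at 9%, between -5% and 24%.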

Compound 3, a percentage reported as inhibition, at one concentration (the size of the read-out at that concentration, not a potency): 1%
Estimate against measurement, compound 3: 8 percentage points above; the range from low to high includes it.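

In this assay, for the compounds shown here, carboxymethyl in place of cyclopentyl on an amide-type nitrogen gives a number 15 percentage points lower from compound 1 to compound 3 (beyond the scatter), the first readable step in this set, and it shows that this position is not indifferent to what it carries. With the core of compound 1 unchanged, the modest inhibition of compound 1 is almost lost, and compound 3 stands at 1%. The change removes a carbon ring and brings in a hydrogen-bond donor and acceptor in a single move, so the step cannot be assigned to either part, and nothing shown gives a cause for it.

Compound 2 is reported only as a limit, > 70%, and it differs from compound 1 in more than one place, so it adds nothing on this change. Still open, going by these compounds, is whether a larger carbon ring such as cyclohexyl, a plain longer carbon chain, or an amine at the end of such a chain on the same nitrogen would keep, raise or lower the inhibition seen with cyclopentyl.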